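Isobutyl in Place of Cyclopropyl at the Glucagon Receptor

A few compounds are considered here, and "the series" means these few. Any claim that something is new, unique, unknown or untested is made for them only; others in the source may bear on it.

Measured compounds:
Compound 1, `CCCC(Oc1ccc(-n2cc(C(F)(F)F)cn2)c(C)c1)c1ccc(C(=O)NCCC(=O)O)cc1`, 1900 nM
Compound 2, `O=C(O)CCNC(=O)c1ccc(C(Oc2ccc(-n3cc(C(F)(F)F)cn3)cc2)C2CC2)cc1`, 15000 nM
Compound 3, `CCCC(Oc1ccc(-n2cc3c(n2)CCCC3)cc1)c1ccc(C(=O)NCCC(=O)O)cc1`, 4200 nM

In a functional assay on cells for antagonist activity at Glucagon receptor (Homo sapiens), read by cAMP accumulation, in the presence of a further agent that is not named here (on this read-out lower numbers stand for stronger inhibition and higher numbers for weaker inhibition), compound 2 gives 15000 nM, the highest of the three numbers. The nearest to it is compound 3 at 4200 nM, a gap beyond the usual scatter, and the furthest is compound 1 at 1900 nM, also beyond the scatter. Compound 4 `CC(C)CC(Oc1ccc(-n2cc(C(F)(F)F)cn2)cc1)c1ccc(C(=O)NCCC(=O)O)cc1` differs from compound 2 in a single place: isobutyl in place of cyclopropyl on a saturated chain carbon bound to an aromatic carbon and an oxygen on an aromatic ring. Going by the values given here, no pair of measured compounds differs in only one place, so no measured step guides this change directly. Neither compound 1 nor compound 3 carries the cyclopropyl, and both give lower numbers than compound 2 in this assay, though each also differs from compound 2 elsewhere. On that basis the step is expected to go downward, beyond the scatter, by about a 4.3-fold lower number from compound 2 to compound 4 (0.63 log units; beyond the scatter). Compound 4 is therefore estimated at 3500 nM, with a range from 1200 nM to 10000 nM.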

Compound 4, antagonist equilibrium constant: 3400 nM
For compound 4 the middle estimate is 1.0-fold (0.01 log units) above the measured one; the range from low to high includes it.
By their numbers in this assay, from the lowest: compounds 1, 4 and 3 (each within the scatter of the next, the first and the last beyond it); then compound 2.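

Read in this assay the exchange of cyclopropyl for isobutyl on a saturated chain carbon bound to an aromatic carbon and an oxygen on an aromatic ring brings a 4.4-fold lower number from compound 2 to compound 4 (0.64 log units; beyond the scatter) and so gives the first measured step at this position with the rest of the structure held the same. The position is thus shown to respond to the group it carries, which the earlier compounds could not show, as they differ from one another in more than one place. Nothing at hand offers a reason for the step.

The compounds shown leave open whether the loss of the three-membered ring or the extra carbon carries the change. A cyclobutyl group or a tert-butyl group at this position could help to separate the two.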